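Swapping an Oxazolyl Ring for Chloro in Sulfonamide Benzamides

The source may hold more compounds than are shown below. What is called first, only, known or untested is meant among the compounds shown, and "the series" means these compounds.

Three sulfonamide benzamides have been measured in an ADME assay on microsomes from liver (Homo sapiens) for metabolic stability; on this read-out lower numbers stand for slow clearance and higher numbers for fast clearance. Compound 3 `Cc1noc(CNC(=O)c2ccc(C)c(S(=O)(=O)Nc3ccc(-c4ccno4)cc3)c2)n1` gives 25 mL/min/kg there. Compound 1 `Cc1noc(CNC(=O)c2ccc(C)c(S(=O)(=O)Nc3ccc(Cl)cc3)c2)n1` gives 35 mL/min/kg in this assay. The change between them is chloro in place of 1,2-oxazol-5-yl on an aromatic carbon, and the step of a 1.4-fold higher number from compound 3 to compound 1 (0.15 log units; within the scatter) is a small one. Compound 2 `Cc1ccc(C(=O)NCc2cn(C)nn2)cc1S(=O)(=O)Nc1ccc(-c2ccno2)cc1` differs from compound 3 in its core: 1-methyl-1H-1,2,3-triazol-4-yl in place of 3-methyl-1,2,4-oxadiazol-5-yl on a saturated chain carbon bound to an amide-type nitrogen. For compound 2 the read-out in this assay is a limit of the assay, < 8 mL/min/kg. The step of an at least 3.1-fold higher number from compound 2 to compound 3 (0.49 log units; beyond the scatter) is at least modest.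

Compound 4 `Cc1ccc(C(=O)NCc2cn(C)nn2)cc1S(=O)(=O)Nc1ccc(Cl)cc1` has not yet been measured. Against compound 2 it carries chloro in place of 1,2-oxazol-5-yl on an aromatic carbon, the same change that leads from compound 3 to compound 1. Compound 4 is expected to give 8 mL/min/kg in this assay. The expected step is a number no lower from compound 2 to compound 4 (the limit leaves the size open), which rests on the measured step of a 1.4-fold higher number from compound 3 to compound 1 (0.15 log units; within the scatter) lying within the scatter. On that basis compound 4 is estimated to sit close to the limit of < 8 mL/min/kg in this assay, at which 1 of the 3 values shown sits, most likely between 4 mL/min/kg and 16 mL/min/kg.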

Compound 4, clearance in the Homo sapiens assay: < 9 mL/min/kg
Compound 4 ended at the assay's limit (the forecaster's own chance of this, stated with the estimate: 50%); the middle value lies beyond the limit too.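

In the Homo sapiens assay the values of compound 2 and compound 4 are both limits of the assay, so the step between them cannot be read, and the series does not show whether chloro in place of 1,2-oxazol-5-yl behaves on this core as it does on the core of compound 3. What can be followed across the two cores in the Homo sapiens assay is the other change, 1-methyl-1H-1,2,3-triazol-4-yl in place of 3-methyl-1,2,4-oxadiazol-5-yl, which gives an at least 3.8-fold lower number from compound 1 to compound 4 (0.58 log units; beyond the scatter) and runs the same way on both: the same change on two cores in the Homo sapiens assay, an at least 3.1-fold higher number (0.49 log units; beyond the scatter) from compound 2 to compound 3 and an at least 3.8-fold higher number (0.58 log units; beyond the scatter) from compound 4 to compound 1; the limit leaves it open whether they differ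

In a physicochemical assay for lipophilicity, using the shake flask method, in phosphate buffer, measured as octanol-water partition, at pH 7.4 (on this read-out lower numbers stand for lower lipophilicity and higher numbers for higher lipophilicity), compound 2 gives 2.4 and compound 4 gives 2.9 so the chloro change can be read on the core of compound 2: the measured distribution coefficient of compound 2, 2.4, and of compound 4, 2.9, a number 0.50 log units higher (beyond the scatter)

The compounds shown leave open whether a methoxy group or a nitrile in place of chloro would follow the same course in the Homo sapiens assay. They also leave open the actual clearance of compound 2 and compound 4, and with it any comparison between those two compounds.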